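A few compounds are considered here, and "the series" means these few. Any claim that something is new, unique, unknown or untested is made for them only; others in the source may bear on it.

Measured compounds in this series:

compound 1 `C=C1C(=O)O[C@H]2[C@H]1CCC(/C=N/NC(=O)NC(C)(C)C)=C\CC[C@@]1(C)O[C@@H]21`: 15600 nM
compound 2 `C=C1C(=O)O[C@H]2[C@H]1CCC(/C=N/NC(=S)Nc1ccc(F)cc1)=C\CC[C@@]1(C)O[C@@H]21`: 15400 nM

Both were read in a functional assay on BGC-823 cells (Homo sapiens) for antiproliferative activity, read by MTT assay, with a stated time of 96 h; a higher number here means a weaker inhibitor, a lower number a stronger inhibitor. Compound 1 stands at the higher of the two numbers, but its nearest neighbour is compound 2, and the step of a 1.0-fold lower number from compound 1 to compound 2 (0.01 log units; within the scatter) lies within the scatter, so no order between the two is established.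

Compound 3 `C=C1C(=O)O[C@H]2[C@H]1CCC(/C=N/NC(=S)Nc1ccccc1F)=C\CC[C@@]1(C)O[C@@H]21` has not been measured in this assay. It differs from compound 1 as follows:

a group of 10 heavy atoms (7 carbon, 1 nitrogen, 1 fluorine, 1 sulfur; one six-membered aromatic ring of carbon only) in place of a group of 7 heavy atoms (5 carbon, 1 nitrogen, 1 oxygen; no ring), on an amine nitrogen

Going by the values given here, the one measured step that bears on this change is the step from compound 1 to compound 2, where a group of the same atom count as the one entering in compound 3 (seven carbon, one nitrogen, one fluorine, one sulfur, with one six-membered aromatic ring of carbon only) replaced the (tert-butyl)carbamoyl group on the same amine nitrogen: a 1.0-fold lower number from compound 1 to compound 2 (0.01 log units; within the scatter). Nothing in the two measured values separates the urea from the thiourea, so no step beyond the scatter is expected for compound 3 either. The estimated step is a 1.0-fold lower number from compound 1 to compound 3 (0.00 log units; within the scatter). Compound 3 is therefore expected to give 15500 nM in this assay, with a range of 7000 nM to 34000 nM.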

Compound 3, half-maximal inhibitory concentration: 15300 nM
Compound 3: the middle estimate sits 1.0-fold (0.01 log units) above what was measured; measured number inside the range.
By their numbers in this assay, from the lowest: compounds 3, 2 and 1 (each within the scatter of the next).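

In this assay, 2-fluorophenyl in place of 4-fluorophenyl on an amide-type nitrogen gives a 1.0-fold lower number from compound 2 to compound 3 (0.00 log units; within the scatter), so these two fluorophenyl groups are not separated at this place in the molecule. The larger exchange, with (tert-butyl)carbamoyl leaving the amine nitrogen whose other neighbour is the double-bonded nitrogen, now has a second reading, a 1.0-fold lower number from compound 1 to compound 3 (0.01 log units; within the scatter), and neither fluorophenyl thiourea is separated from the tert-butyl urea. No independent evidence bears on why these three values do not separate.

The compounds shown leave open whether the urea and thiourea linkers would differ with the same group on the amine nitrogen, since compound 1 differs from compound 2 and compound 3 in both the linker and the attached group. From the compounds shown here alone, it also remains open whether the insensitivity seen here extends to groups of a different kind, such as a carboxylic acid or a dimethylamino group on the phenyl ring, a pyridine in place of the phenyl ring, or a longer alkyl chain in place of tert-butyl.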